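Working notes on the step from compound 3 to compound 4

This account rests on a few compounds, and the source may have more. Where it says the series, first, only, none or still open, it means among the compounds named here.

The series shares one core, carried in compound 1 `Oc1ccccc1/C=N/N=C(\S)Nc1ncc(C2CCC2)o1`, which in a functional assay on Vero cells (Chlorocebus sabaeus) for cytotoxicity (a lower number here means a stronger inhibitor, a higher number a weaker inhibitor), has "not determined" (no result reported). Compound 2 `O=[N+]([O-])c1cccc(/C=N/N=C(\S)Nc2ncc(C3CCC3)o2)c1` is reported in this assay only as a limit of the assay, not a number: compound 2 gives < 62.5 ug/mL. Compound 3 `O=[N+]([O-])c1ccc(/C=N/N=C(\S)Nc2ncc(C3CCC3)o2)cc1` likewise stands at a limit in this assay, where compound 3 gives < 62.5 ug/mL. Because of the limit of < 62.5 ug/mL in this assay, at which 2 of the 3 values shown sit, no single number places compound 3 within the set; two of three entries rest at the same limit and the third has no value at all. Compound 4 `Cc1ccc(/C=N/N=C(\S)Nc2ncc(C3CCC3)o2)cc1` differs from compound 3 by methyl in place of nitro on an aromatic carbon. For the measured compounds named here, no measured step between neighbouring compounds exists to guide the size of this change, so no direction beyond the scatter is expected and the step that the limit leaves unreadable from compound 3 to compound 4 is taken as an expectation only. For compound 4 the estimated reading in this assay is 40 ug/mL, with a range from 10 ug/mL to 125 ug/mL, and a result reported only as a limit is expected to be the likeliest outcome.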

Compound 4, half-maximal inhibitory concentration: < 62.5 ug/mL
Compound 4 ended at the assay's limit; the forecaster's own chance of this, stated with the estimate: 60%; the middle value is on the limit's open side.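

No step from compound 3 to compound 4 can be read in this assay, since both compounds stand at a limit of the assay and not at a number: the limit of < 62.5 ug/mL in this assay, at which 3 of the 4 values shown sit.

The compounds shown leave open whether methyl in place of nitro on an aromatic carbon shifts the reading in this assay at all.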